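The source may report more compounds than this note shows. Statements on the series, on what has been measured and on what is new or still open speak of the compounds shown alone.

Measured so far:
Compound 1, `CNc1cc(Oc2c(OC)cc3cc(C#N)ccc3c2OC)nc(Nc2ccc(C#N)cc2)n1`, gives 239000 nM in an ADME assay on MT4 cells (Homo sapiens) for cytotoxicity, read by MTT assay, with a stated time of 5 days; on this read-out lower numbers stand for higher toxicity in this test and higher numbers for lower toxicity in this test.
Compound 2, `CCCCCC(C)Nc1cc(Oc2c(OC)cc3cc(C#N)ccc3c2OC)nc(Nc2ccc(C#N)cc2)n1`, is recorded in this assay only as a limit, > 125000 nM.
Compound 3, `COc1cc2cc(C#N)ccc2c(OC)c1Oc1cc(NCCCOC(C)C)nc(Nc2ccc(C#N)cc2)n1`, is recorded in this assay only as a limit, > 125000 nM.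

Compound 3 therefore stands not at a number but at the ceiling of the measurement, and one further value of the three shares that ceiling. The two steps leading to it, a step that the limit leaves unreadable from compound 1 to compound 3 and a step that the two limits leave unreadable from compound 2 to compound 3, cannot be sized, and neither can a step that the limit leaves unreadable from compound 1 to compound 2, because of the limit of > 125000 nM in this assay, at which 2 of the 3 values shown sit.

Compound 4, `COc1cc2cc(C#N)ccc2c(OC)c1Oc1cc(NCC2CCOC2)nc(Nc2ccc(C#N)cc2)n1`, differs from compound 3 at the saturated chain carbon bound to the nitrogen on the aromatic ring: oxolan-3-yl in place of 2-isopropoxyethyl on a saturated chain carbon bound to a nitrogen on an aromatic ring. An open chain with one oxygen gives way to a five-membered non-aromatic ring with one hetero atom, the count of hydrogen-bond acceptors staying the same.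

No readable step bears on this change, so no direction can be drawn from the measured compounds. Compound 3 and compound 2 both sit at the limit, and compound 1 lies close to it, so the expected step that the limit leaves unreadable from compound 3 to compound 4 is none beyond the scatter. Compound 4 is estimated at 200000 nM, within a range of 100000 nM to 400000 nM, and will most likely again be reported only as a limit.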

Compound 4, half-maximal cytotoxic concentration: > 125000 nM
Compound 4: only a limit was reported; the forecaster's own chance of this, stated with the estimate: 70%; the middle value does not contradict the limit.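

Compound 4 joins compound 2 and compound 3 as a limit rather than a number, so none of its steps to these two compounds or to compound 1 can be read, because of this ceiling: the limit of > 125000 nM in this assay, at which 3 of the 4 values shown sit.

The compounds shown leave open whether changing the group on the nitrogen alters the outcome in this assay at all.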